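The source may report more compounds than this note shows. Statements on the series, on what has been measured and on what is new or still open speak of the compounds shown alone.

Measured in a physicochemical assay for solubility, at pH 1.1; on this read-out lower numbers stand for lower solubility and higher numbers for higher solubility:
- compound 1 `CCCN(Cc1ccc(OCCn2c(=O)ccn(C)c2=O)c(OC)c1)C(CC(=O)O)c1ccc(Cl)cc1`: 3000000 nM
- compound 2 `COc1cc(CN(CC2CC2)C(CC(=O)O)c2ccc(Cl)cc2)ccc1OCCn1c(=O)ccn(C)c1=O`: 3000000 nM
- compound 3 `COc1cc(CN(C2CCC2)C(CC(=O)O)c2ccc(Cl)cc2)ccc1OCCn1c(=O)ccn(C)c1=O`: 3000000 nM

Compound 3 stands level with compound 1 and compound 2 at the digits shown. The next compound, compound 4 `CCCCN(Cc1ccc(OCCn2c(=O)ccn(C)c2=O)c(OC)c1)C(CC(=O)O)c1ccc(Cl)cc1`, has not yet been measured. It differs from compound 3 by one change: butyl in place of cyclobutyl on an amine nitrogen. Three measured steps alter the group on that nitrogen: no change at the digits printed from compound 1 to compound 3 (within the scatter), no change at the digits printed from compound 2 to compound 3 (within the scatter) and no change at the digits printed from compound 1 to compound 2 (within the scatter). None of them leaves the scatter, so no change beyond the scatter is expected in this assay. The expected step is no change at the digits printed from compound 3 to compound 4 (within the scatter). The estimated value for compound 4 is 3000000 nM. Its expected range runs from 1500000 nM to 4000000 nM.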

Compound 4, solubility: 3000000 nM
The estimate for compound 4 equals the measured number at the digits printed, within the range that was stated.
By their numbers in this assay, from the lowest: compounds 1, 2, 3 and 4 (each within the scatter of the next).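

In this assay, butyl in place of cyclobutyl on the amine nitrogen, a ring opened at the same count of heavy atoms, gives no change at the digits printed from compound 3 to compound 4 (within the scatter). The open chain also stands level with the other two groups, with no change at the digits printed from compound 1 to compound 4 (within the scatter) and no change at the digits printed from compound 2 to compound 4 (within the scatter), so across these four compounds neither a ring nor an added carbon on this nitrogen's chain moves the read-out beyond the scatter. No supporting data bear on this result. The compounds shown leave open whether a hydroxyl group or an amine on that chain would shift this assay.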